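A few compounds are considered here, and "the series" means these few. Any claim that something is new, unique, unknown or untested is made for them only; others in the source may bear on it.

In a functional assay on HOS cells (Homo sapiens) for inhibition, with a stated time of 72 h (on this read-out lower numbers stand for stronger inhibition and higher numbers for weaker inhibition), compound 2 `NC1CCC(Nc2nc(NCc3ccc(-c4ccco4)cc3)c3ncn(C4CCCC4)c3n2)CC1` gives 102 nM and compound 1 `COc1ccccc1-c1ccc(CNc2nc(NC3CCC(N)CC3)nc3c2ncn3C2CCCC2)cc1` gives 150 nM, two values within the scatter of each other, while compound 3 `CC(C)(O)CNc1nc(NCc2ccc(-c3ccco3)cc2)c2ncn(C3CCCC3)c2n1` gives 21400 nM and stands far higher. Compound 4 `NC1CCC(Nc2nc(NCc3cc(Cl)ccc3O)c3ncn(C4CCCC4)c3n2)CC1` has 5-chloro-2-hydroxyphenyl in place of 4-(furan-2-yl)phenyl on a saturated chain carbon bound to a nitrogen on an aromatic ring. Within the data shown here, two measured steps bear on this. Putting furan-2-yl in place of 2-methoxyphenyl gave a step within the scatter (a 1.5-fold lower number from compound 1 to compound 2 (0.17 log units; within the scatter)), but that swap replaced one ring, not the whole group. The large step (a 210-fold higher number from compound 2 to compound 3 (2.32 log units; beyond the scatter)) removed 4-aminocyclohexyl, which compound 4 keeps. A moderate rise in this assay is therefore expected (a 3.9-fold higher number from compound 2 to compound 4 (0.59 log units; beyond the scatter)), far smaller than that large step. The estimated value for compound 4 is 400 nM (expected range 80 nM to 2500 nM).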

Compound 4, half-maximal inhibitory concentration: 490 nM
The estimate for compound 4 lay 1.2-fold (0.09 log units) below the measured number; the measured number falls inside the stated range.
By their numbers in this assay, from the lowest: compounds 2 and 1 (each within the scatter of the next); then compound 4; then compound 3.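

In this assay, the whole 4-(furan-2-yl)phenyl group can be replaced at this place by 5-chloro-2-hydroxyphenyl, with one aromatic ring fewer, at only a modest cost (a 4.8-fold higher number from compound 2 to compound 4 (0.68 log units; beyond the scatter)). The earlier step at this place changed only the outer ring, whereas this one shows that the outer ring can be absent altogether while the number rises only modestly. Nothing measured here explains the rise. As far as these compounds go, the chlorine and the hydroxyl enter together, so their separate shares of the step stay open. A phenyl carrying only one of them would separate the two.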